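A few compounds are considered here, and "the series" means these few. Any claim that something is new, unique, unknown or untested is made for them only; others in the source may bear on it.

Among the compounds with values here, the two compounds measured so far are compound 1 `CCN(CC)CCCOc1cc2ncnc(Nc3nc4ccc(C(=O)Nc5c(C)cccc5C)cc4s3)c2cc1OC` and compound 2 `COc1cc2c(Nc3nc4ccc(C(=O)Nc5c(C)cc(C)cc5C)cc4s3)ncnc2cc1OCCCN1CCCC1`. In a functional assay on U-937 cells (Homo sapiens) for cytotoxicity, read by WST assay, with a stated time of 72 h (on this read-out lower numbers stand for stronger inhibition and higher numbers for weaker inhibition), compound 1 gives 23700 nM, and in the same assay compound 2 gives 4600 nM. Compound 2 therefore stands with the lowest of the two numbers, and its gap to compound 1 lies beyond the scatter. Within the data shown here, compound 1 and compound 2 differ in more than one place, so no single step between them can be read off.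

Compound 3 `COc1cc2c(Nc3nc4ccc(C(=O)Nc5c(C)cccc5C)cc4s3)ncnc2cc1OCCCN1CCCC1` has not yet been measured in this assay. It differs from compound 2 in one place: hydrogen in place of methyl on an aromatic carbon, so that the 2,4,6-trimethylphenyl of compound 2 becomes the 2,6-dimethylphenyl that compound 1 also carries. Compound 1 shows a higher number than compound 2, but its chain differs as well. How much of that gap goes with this one change cannot be told from the two values alone. Compound 3 is expected to give a higher number than compound 2, a step of a 2.0-fold higher number from compound 2 to compound 3 (0.29 log units; within the scatter), held loosely. The estimate for compound 3 in this assay is 9000 nM, within a range from 3000 nM to 30000 nM.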

Compound 3, half-maximal inhibitory concentration: 18900 nM
Compound 3: the middle estimate sits 2.1-fold (0.32 log units) below what was measured; the measured number falls inside the stated range.
By their numbers in this assay, from the lowest: compound 2; then compounds 3 and 1 (each within the scatter of the next).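

The added methyl matters in this assay: on the aromatic carbon para to a large group, hydrogen in place of methyl gives a 4.1-fold higher number from compound 2 to compound 3 (0.61 log units; beyond the scatter), a step beyond the scatter. At the other end of the molecule, pyrrolidin-1-yl in place of diethylamino on the saturated chain gives a 1.3-fold lower number from compound 1 to compound 3 (0.10 log units; within the scatter), which lies within the scatter, so the two amine ends are not told apart on this 2,6-dimethylphenyl background. Within the data shown here, of the two single changes now readable, only the one at the methyl moves the number beyond the scatter, which the earlier pair, differing in two places, could not show. Nothing at hand accounts for the size of either step.

Going by these compounds, whether the lower number of compound 2 is particular to methyl remains open, since an ethyl, a methoxy or a chlorine on that same aromatic carbon would test how far the step depends on the group there. On these data alone, it is also open whether the methyl step carries over to the diethylamino chain, and whether a morpholine or a piperazine at the chain end, or a longer chain, would stay as close to pyrrolidin-1-yl as diethylamino does.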